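Adding one chain carbon to compound 1

A few compounds are considered here, and "the series" means these few. Any claim that something is new, unique, unknown or untested is made for them only; others in the source may bear on it.

compound 1 `Nc1ncnc2c1c(-c1cnc3[nH]ccc3c1)nn2CCCCCCCCC(=O)NO` gives 7470 nM
compound 2 `Nc1nc2cc(-c3nn(CCCC(=O)NO)c4ncnc(N)c34)ccc2o1` gives > 150000 nM (a limit)
compound 3 `Nc1nc2cc(-c3nn(CCCCCCCCCC(=O)NO)c4ncnc(N)c34)ccc2o1` gives > 50000 nM (a limit)

Going by the values given here, in a functional assay on HeLa cells (Homo sapiens) for inhibition, read by MTT assay, with a stated time of 72 h (a lower number here means a stronger inhibitor, a higher number a weaker inhibitor), compound 1 gives 7470 nM as the only true number. The other two results are limits. Compound 4 `Nc1ncnc2c1c(-c1cnc3[nH]ccc3c1)nn2CCCCCCCCCC(=O)NO` keeps the core of compound 1 and puts (hydroxycarbamoyl)methyl in place of hydroxycarbamoyl on a saturated chain carbon, eight bonds along the chain from an aromatic nitrogen. This lengthens the chain by one carbon.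

Among the compounds with values here, the only measured change of chain length is a step that the two limits leave unreadable from compound 2 to compound 3 and it offers no size to carry over. Compound 4 shares its chain with compound 3, which reads > 50000 nM as a limit, but compound 3 has a different core. The estimate therefore rests on compound 1 at 7470 nM in this assay and assumes that one added carbon does little. The expected change, a 1.2-fold higher number from compound 1 to compound 4 (0.08 log units; within the scatter), stays within the scatter, with no firm direction. For compound 4 the estimate is 9000 nM, with an expected range from 3000 nM to 30000 nM in this measurement.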

Compound 4, half-maximal inhibitory concentration: 7560 nM
Beside the measured number, compound 4's estimate is 1.2-fold (0.08 log units) above it; the measured number falls inside the stated range.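

In this assay, the step of one added chain carbon on the shared core is a 1.0-fold higher number from compound 1 to compound 4 (0.01 log units; within the scatter), which gives the first readable size for a change of chain length, at this place on a saturated chain carbon, eight bonds along the chain from an aromatic nitrogen. With the chain held the same, changing the group on the aromatic carbon gives an at least 6.6-fold lower number from compound 3 to compound 4 (0.82 log units; beyond the scatter), so in this pair that group carries a step beyond the scatter. That step rests on a limit for compound 3, not on a true number: the limit of > 50000 nM in this assay, at which 1 of the 4 values shown sits.

The step from compound 2 to compound 3 cannot be read, so the compounds shown give no trend in chain length on either core. From the compounds shown here alone, what 3-(hydroxycarbamoyl)propyl on the core of compound 1, or a carboxylic acid in place of hydroxycarbamoyl, would give stays open.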